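Efficacy notes: amide in place of the acid of compound 1

The source may report more compounds than this note shows. Statements on the series, on what has been measured and on what is new or still open speak of the compounds shown alone.

Measured compounds:
compound 1 `Cc1nc(-c2ccc(C(F)(F)F)cc2)sc1CNc1ccc(CC(=O)O)cc1`: 18%
compound 2 `O=C(O)[C@H]1C[C@@H]1c1ccc(NCc2cccc(Oc3ccccc3)c2)cc1`: 88%; 72% (2 entries)
compound 3 `CC(CC(=O)O)c1ccc(NCc2cccc(Oc3ccccc3)c2)cc1`: 83%

In a functional assay on CHO cells for agonist activity at Free fatty acid receptor 1 (Homo sapiens), read by a luciferase reporter (on this read-out lower numbers stand for smaller maximal responses and higher numbers for larger maximal responses), compound 1 gives 18%, the lowest of the two single numbers. Compound 3 gives 83%, which lies beyond the scatter above compound 1. Compound 2 has several entries, (the several entries of compound 2 in this assay, 88%; 72% (2 entries)), all high. Among the compounds with values here, compounds 2 and 3 share a core that differs from that of compound 1, and no pair among the three differs in a single place, so no measured step isolates any one change.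

Compound 4 `Cc1nc(-c2ccc(C(F)(F)F)cc2)sc1CNc1ccc([C@H]2C[C@@H]2C(=O)N(C)C)cc1` keeps the core of compound 1 and differs from it by 2-(dimethylcarbamoyl)cyclopropyl in place of carboxymethyl on an aromatic carbon. Within the data shown here, no measured step covers this change, and no step among the measured compounds holds an acid being replaced by an amide. The expected step in this assay from compound 1 to compound 4, a number 6 percentage points lower from compound 1 to compound 4 (within the scatter), is downward or none beyond the scatter, starting from an already small maximal response. For compound 4 the estimate in this assay is 12%, in the range 0% to 40%.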

Compound 4, largest response reached (reported as percent of maximum), in percent of the reference or control that the assay uses: 49%
Estimate against measurement, compound 4: 37 percentage points below; the measured number lies above the stated range.
By their numbers in this assay, from the lowest: compound 1; then compound 4; then compound 3.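

In this assay, putting 2-(dimethylcarbamoyl)cyclopropyl in place of carboxymethyl on an aromatic carbon, para to a large group, gives a number 31 percentage points higher from compound 1 to compound 4 (beyond the scatter). On the core of compound 1, a substantial maximal response at this position therefore does not depend on a carboxylic acid, and the group with no hydrogen-bond donor gives the larger response. The other cyclopropyl compound, compound 2, carries a carboxylic acid on a different core, forms no readable step with compound 4, and stays high: the several entries of compound 2 in this assay, 88%; 72% (2 entries)

The step changes the ring and the amide at once and does not separate their contributions. Open, from the compounds shown here alone, is where dimethylcarbamoylmethyl, the amide without the ring, or 2-carboxycyclopropyl, the ring with the acid, would stand on the core of compound 1.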